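Aryl for Alkyl on a Triazole Nitrogen

The source may hold more compounds than are shown below. What is called first, only, known or untested is meant among the compounds shown, and "the series" means these compounds.

Measured compounds:
Compound 1, `CCOC(=O)C1=Cc2ccccc2OC1(OCc1cn(-c2cccc(OC)c2)nn1)C(F)(F)F`: in a functional assay on DU-145 cells (Homo sapiens) for inhibition, read by MTT assay, with a stated time of 24 h (on this read-out lower numbers stand for stronger inhibition and higher numbers for weaker inhibition), compound 1 gives > 150000 nM, a limit of the assay.
Compound 2, `CCCCCCCCn1cc(COC2(C(F)(F)F)Oc3ccccc3C=C2C(=O)OCC)nn1`: in this assay compound 2 gives > 150000 nM, likewise a limit.
Compound 3, `CCOC(=O)C1=Cc2ccccc2OC1(OCc1cc(-c2ccc3ccccc3c2)no1)C(F)(F)F`: in this assay compound 3 gives 71800 nM.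

Compound 2 thus stands at the limit of this assay; its value is one of those described by the limit of > 150000 nM in this assay, at which 2 of the 3 values shown sit. Compound 4, `CCOC(=O)C1=Cc2ccccc2OC1(OCc1cn(-c2ccc(F)c(Cl)c2)nn1)C(F)(F)F`, is the next compound to be measured; it differs from compound 2 by 3-chloro-4-fluorophenyl in place of octyl on an aromatic nitrogen. For the measured compounds named here, only one measured step touches this place, a step that the two limits leave unreadable from compound 1 to compound 2, and its size cannot be read because both of its ends sit at the limit of > 150000 nM in this assay, at which 2 of the 3 values shown sit. Going by the values given here, compound 3, which carries its aryl group on a different ring of the shared core, is the only compound that gives a number rather than a limit, and no step connects it to compound 4. The aryl-bearing compound 1 and the alkyl-bearing compound 2 both return limits, so compound 4 is expected to remain at or near the limit as well. Compound 4 is therefore estimated at 150000 nM, with a range from 70000 nM to 400000 nM, and will most likely be reported as a limit. The expected step of a number no higher from compound 2 to compound 4 (the limit leaves the size open) is estimated to be none beyond the scatter.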

Compound 4, half-maximal inhibitory concentration: 21500 nM
Estimate against measurement, compound 4: 7.0-fold (0.84 log units) above; the measured number lies below the stated range.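

At this aromatic nitrogen, this assay now gives a readable change: 3-chloro-4-fluorophenyl in place of octyl brings an at least 6.9-fold lower number from compound 2 to compound 4 (0.84 log units; beyond the scatter), and the same group in place of 3-methoxyphenyl brings an at least 6.9-fold lower number from compound 1 to compound 4 (0.84 log units; beyond the scatter). The second step shows that an aryl group here does not by itself move the read-out off the limit, since compound 1 also carries one, so the groups on that phenyl ring make a difference among the compounds shown. Both steps start from a limit of the assay, so their true sizes are unknown, and the earlier step between the octyl and 3-methoxyphenyl compounds cannot be read because both of its ends sit at that limit: the limit of > 150000 nM in this assay, at which 2 of the 4 values shown sit.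

The compounds shown do not separate the part played by the chlorine from that played by the fluorine, as each appears only in the one 3-chloro-4-fluorophenyl group. As far as these compounds go, it also stays open how a phenyl ring carrying only one of these halogens, or an amine or a carboxylic acid instead, would read at this nitrogen.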